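Amide variation on the hydroxyphenyl triazole series

This account rests on a few compounds, and the source may have more. Where it says the series, first, only, none or still open, it means among the compounds named here.

Measured compounds:
Compound 1, `CCCCCCc1cn(-c2ccc(O)c(C(=O)NCCC)c2)nn1`, in a functional assay on RAW264.7 cells (Mus musculus) for inhibition, read by Griess assay, with a stated time of 20 h (on this read-out lower numbers stand for stronger inhibition and higher numbers for weaker inhibition), gives 19700 nM.
Compound 2, `CCCCCCc1cn(-c2ccc(O)c(C(=O)N3CCCCC3)c2)nn1`, in this assay reaches only the limit of > 20000 nM.
Compound 3, `CCCNC(=O)c1ccc(-n2cc(-c3ccccc3)nn2)cc1O`, in this assay reaches only the limit of > 20000 nM.

Among the compounds with values here, the one step measured within this set is piperidin-1-yl in place of propylamino on a carbonyl carbon; in this assay it reads an at least 1.0-fold higher number from compound 1 to compound 2 (0.00 log units; that floor lies within the scatter). This step rests on a limit, since (the limit of > 20000 nM in this assay, at which 2 of the 3 values shown sit), so its true size is open and only its floor is known. Compound 1 and compound 3 share the hydroxyphenyl triazole core but the difference between the two cores is not broken down here; what the two values show is that compound 1 gives a number and compound 3 gives only a limit.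

The unmeasured compound 4, `O=C(c1ccc(-n2cc(-c3ccccc3)nn2)cc1O)N1CCCCC1`, stands to compound 3 as compound 2 stands to compound 1: the change is piperidin-1-yl in place of propylamino on a carbonyl carbon, the same change at the same place, a carbonyl carbon whose other neighbours are an aromatic carbon. With compound 3 already at a limit in this assay, and the step from compound 1 to compound 2 having moved the number no lower, compound 4 is expected to stay at or beyond that limit, an estimated step that the limit leaves unreadable from compound 3 to compound 4. For compound 4 in this assay the estimate is 35000 nM, expected to fall between 15000 nM and 100000 nM, most likely reported again as a limit rather than a number.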

Compound 4, half-maximal inhibitory concentration: > 20000 nM
Compound 4: no number, only a limit; the forecaster's own chance of this, stated with the estimate: 85%; the middle value lies beyond the limit too.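

Compound 3 and compound 4 both stop at a limit in this assay, so the change from propylamino to piperidin-1-yl gives no new readable step between them: the limit of > 20000 nM in this assay, at which 3 of the 4 values shown sit.

The compounds shown leave open the true values of compound 2, compound 3 and compound 4, and so how far this change moves the number with either the hexyl-bearing core of compound 1 or the core of compound 3.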